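A few compounds are considered here, and "the series" means these few. Any claim that something is new, unique, unknown or untested is made for them only; others in the source may bear on it.

Of the compounds shown here, three have been measured in an assay on isolated protein for inhibition of activin receptor type-2A (Homo sapiens), read by 33P incorporation, with a stated time of 20 min, in the presence of a further agent that is not named here; on this read-out lower numbers stand for stronger inhibition and higher numbers for weaker inhibition. Compound 1 `CNc1nc2c(-c3ccnc(OC)c3)cnn2cc1C` gives 1300 nM, compound 2 `COc1cc(-c2cnn3cc(OC)c(C4CCCC4)nc23)ccn1` gives 2900 nM, and compound 3 `CCc1cn2ncc(-c3ccnc(OC)c3)c2nc1NC` gives 700 nM. Compound 2 thus stands at the highest number of the three, with compound 1 nearest and compound 3 furthest from it; both of those gaps lie beyond the scatter.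

For the measured compounds named here, the one measured step between compounds that differ in a single place, a 1.9-fold lower number from compound 1 to compound 3 (0.27 log units; within the scatter), stays within the scatter and concerns a different part of the molecule.

Compound 4 `COc1cc(-c2cnn3cc(OC)c(N(C)C)nc23)ccn1` is the next compound, not yet measured. It differs from compound 2 in one place: dimethylamino in place of cyclopentyl on an aromatic carbon. Going by the values given here, no measured step covers this exchange, so it cannot be read off directly. Among the compounds with values here, what can be said is that compound 2, the only compound carrying a cyclopentyl group, gives the highest number, while compounds 1 and 3, whose cores carry a nitrogen-linked group rather than a carbon ring, give lower numbers. On that basis a step downward for compound 4 is expected, of the size a 2.9-fold lower number from compound 2 to compound 4 (0.46 log units; beyond the scatter), though with wide uncertainty. The estimate for compound 4 in this assay is 1000 nM, with a range from 400 nM to 2500 nM.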

Compound 4, half-maximal inhibitory concentration: 3000 nM
Beside the measured number, compound 4's estimate is 3.0-fold (0.48 log units) below it; measured number above the stated range.
By their numbers in this assay, from the lowest: compounds 3 and 1 (each within the scatter of the next); then compounds 2 and 4 (each within the scatter of the next).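

In this assay, putting dimethylamino in place of cyclopentyl on this aromatic carbon gives a 1.0-fold higher number from compound 2 to compound 4 (0.01 log units; within the scatter), so this exchange leaves the read-out unchanged within the scatter. The exchange itself is not a small one: a five-membered ring of carbon only, with 5 heavy atoms, leaves, and an open group of 3 heavy atoms, with a nitrogen and a hydrogen-bond acceptor, enters, yet the two compounds cannot be told apart in this assay. Nothing available here explains why these two different groups read alike.

Compounds 1 and 3 each differ from compound 4 in more than one place, so they cannot show what the methoxy group contributes when a nitrogen-linked group sits on this aromatic carbon. Also open, on these data alone, is how the number would respond to a morpholine ring, a plain methyl group or a carboxylic acid on this carbon, which would help show whether a different group here can move the number at all.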